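The source may report more compounds than this note shows. Statements on the series, on what has been measured and on what is new or still open speak of the compounds shown alone.

Values in a functional assay on HT-29 cells (Homo sapiens) for inhibition, read by CCK-8 assay, with a stated time of 24 h (on this read-out higher numbers stand for weaker inhibition and lower numbers for stronger inhibition), for the measured compounds:
- compound 1 `Cc1ccccc1-n1cc(-c2ccc(/C=C3\C(=O)Nc4ccccc43)cc2)nn1` gives 8710 nM
- compound 2 `O=C1Nc2ccccc2/C1=C/c1ccc(-c2cn(-c3ccccc3F)nn2)cc1` gives 10500 nM
- compound 3 `O=C1Nc2ccccc2/C1=C/c1ccc(-c2cn(-c3cccc(F)c3)nn2)cc1` gives > 20000 nM (a limit)

Compound 3 gives > 20000 nM as a limit of this assay and not as a number. Compound 4 `O=C1Nc2ccccc2/C1=C/c1ccc(-c2cn(-c3ccccc3Cl)nn2)cc1` carries 2-chlorophenyl in place of 3-fluorophenyl on an aromatic nitrogen. Between the 2-methylphenyl of compound 1 and the 2-fluorophenyl of compound 2 the step is small (a 1.2-fold higher number from compound 1 to compound 2 (0.08 log units; within the scatter)), and the steps to 3-fluorophenyl are modest (an at least 2.2-fold higher number from compound 1 to compound 3 (0.36 log units; beyond the scatter); an at least 1.9-fold higher number from compound 2 to compound 3 (0.27 log units; that floor lies within the scatter)). A modest step to a lower number, meaning stronger inhibition, is therefore expected (an at least 2.0-fold lower number from compound 3 to compound 4 (0.30 log units; that floor lies within the scatter)). Compound 4 is estimated at 10000 nM within an expected range from 5000 nM to 19000 nM on this read-out.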

Compound 4, half-maximal inhibitory concentration: > 20000 nM
Compound 4 gave a limit, no number; the forecaster's own chance of this, stated with the estimate: 12%; middle value at least 2.0-fold (0.30 log units) from the limit.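

In this assay, 2-chlorophenyl on the aromatic nitrogen does not hold the level of 2-methylphenyl: chloro in place of methyl gives an at least 2.2-fold higher number from compound 1 to compound 4 (0.36 log units; beyond the scatter). Chloro in place of fluoro gives an at least 1.9-fold higher number from compound 2 to compound 4 (0.27 log units; that floor lies within the scatter), so the gap to compound 2 is not shown to exceed the scatter. The step between compound 3 and compound 4 cannot be read: the limit of > 20000 nM in this assay, at which 2 of the 4 values shown sit.

From the compounds shown here alone, whether compound 3 and compound 4 differ at all remains open. Also open, going by these compounds, is how an amine or a carboxylic acid on this phenyl would read against compound 1.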